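Aryl amide variation on the enone series: compound 4

The source may hold more compounds than are shown below. What is called first, only, known or untested is meant among the compounds shown, and "the series" means these compounds.

Compound 1 `O=C(/C=C/c1cccc(NC(=O)c2ccccc2Cl)c1)c1nc2ccccc2[nH]1` carries a 2-chlorophenyl group on the amide carbonyl carbon. For the measured compounds named here, in a functional assay on HCT-116 cells (Homo sapiens) for antiproliferative activity, read by MTT assay, with a stated time of 48 h (on this read-out higher numbers stand for weaker inhibition and lower numbers for stronger inhibition), compound 1 gives 1280 nM, the lowest of the three numbers so far, though both other compounds sit within the scatter of it. Compound 2 `Cc1ccc(C(=O)Nc2cccc(/C=C/C(=O)c3nc4ccccc4[nH]3)c2)cc1` gives 1660 nM and compound 3 `O=C(Nc1cccc(/C=C/C(=O)c2nc3ccccc3[nH]2)c1)c1cc(Cl)cc(Cl)c1` gives 1650 nM; the steps of a 1.3-fold higher number from compound 1 to compound 2 (0.11 log units; within the scatter) and a 1.3-fold higher number from compound 1 to compound 3 (0.11 log units; within the scatter) are both small, as is a 1.0-fold lower number from compound 2 to compound 3 (0.00 log units; within the scatter). Compound 4 `Cc1cc(C)cc(C(=O)Nc2cccc(/C=C/C(=O)c3nc4ccccc4[nH]3)c2)c1` differs from compound 1 by 3,5-dimethylphenyl in place of 2-chlorophenyl on a carbonyl carbon. Exchanging the aryl group on this carbonyl has so far left the numbers essentially unchanged, so for compound 4 no movement beyond the scatter is expected, a 1.2-fold higher number from compound 1 to compound 4 (0.07 log units; within the scatter). Compound 4 is therefore estimated at 1500 nM, with a range from 800 nM to 2800 nM.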

Compound 4, half-maximal inhibitory concentration: 1550 nM
Compound 4: middle estimate off by 1.0-fold (0.01 log units), on the low side; measured number inside the range.
By their numbers in this assay, from the lowest: compounds 1, 4, 3 and 2 (each within the scatter of the next).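

With 3,5-dimethylphenyl on the carbonyl carbon, an aryl group of carbon only, the number stays within the scatter of the 2-chlorophenyl and 4-methylphenyl compounds (a 1.2-fold higher number from compound 1 to compound 4 (0.08 log units; within the scatter); a 1.1-fold lower number from compound 2 to compound 4 (0.03 log units; within the scatter)). The matched pair 3,5-dimethylphenyl and 3,5-dichlorophenyl adds that methyl and chlorine are not separated on this aryl pattern (a 1.1-fold lower number from compound 3 to compound 4 (0.03 log units; within the scatter)). No supporting data bear on why the numbers stay so close.

All four aryl groups carry only chlorine or methyl. On these data alone, whether an amine, a carboxylic acid or a pyridine ring at this carbonyl carbon would move the number beyond the scatter remains open.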